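Dichlorophenyl on a Tetrazole Nitrogen: Expected Cytotoxicity

The source may hold more compounds than are shown below. What is called first, only, known or untested is meant among the compounds shown, and "the series" means these compounds.

Compound 1, `O=[N+]([O-])c1cc(-c2nnn(Cc3ccccc3F)n2)cc([N+](=O)[O-])c1`: > 200000 nM
Compound 2, `O=[N+]([O-])c1cc(-c2nnn(Cc3ccc(Cl)c(Cl)c3)n2)cc([N+](=O)[O-])c1`: 37000 nM
Compound 3, `O=[N+]([O-])c1cc(-c2nnn(CSc3nnnn3C3CCCCC3)n2)cc([N+](=O)[O-])c1`: 140000 nM

In an ADME assay on CHO-K1 cells (Cricetulus griseus) for cytotoxicity, read by MTT assay, with a stated time of 24 h (on this read-out lower numbers stand for stronger inhibition and higher numbers for weaker inhibition), compound 1 reaches only a limit of the assay, (the limit of > 200000 nM in this assay, at which 1 of the 3 values shown sits). Among the two numbers that are known, compound 3 stands highest; the nearest is compound 2, which gives 37000 nM. The unmeasured compound 4 is `O=[N+]([O-])c1cc(-c2nnn(CSc3nnnn3-c3ccc(Cl)c(Cl)c3)n2)cc([N+](=O)[O-])c1`; the change from compound 3 is 3,4-dichlorophenyl in place of cyclohexyl on an aromatic nitrogen. Going by the values given here, one measured step bears on it: an at least 5.4-fold lower number from compound 1 to compound 2 (0.73 log units; beyond the scatter), where 3,4-dichlorophenyl also entered. A step of similar direction is therefore expected here, of moderate size. Compound 4 is expected to give 50000 nM, from 15000 nM to 160000 nM. This amounts to an expected step of a 2.8-fold lower number from compound 3 to compound 4 (0.45 log units; beyond the scatter).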

Compound 4, half-maximal inhibitory concentration: 8700 nM
The estimate for compound 4 lay 5.7-fold (0.76 log units) above the measured number; measured number below the stated range.
By their numbers in this assay, from the lowest: compound 4; then compound 2; then compound 3. At a limit, above all of these: compound 1.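

On an aromatic nitrogen of a five-membered aromatic ring with 4 nitrogen, 3,4-dichlorophenyl in place of cyclohexyl gives a 16-fold lower number from compound 3 to compound 4 (1.21 log units; beyond the scatter) in this assay, a large step. Until now, 3,4-dichlorophenyl had entered only on a saturated chain carbon, so a lower number now goes with this group at two different places. Nothing measured here gives a cause for this step.

The compounds shown leave open whether the chlorines are needed for the step, or whether an unsubstituted phenyl on the same nitrogen would also give it.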